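The source may hold more compounds than are shown below. What is called first, only, known or untested is meant among the compounds shown, and "the series" means these compounds.

Three compounds share one core and differ only in the aromatic group carried by the amide-type nitrogen in the ring. Compound 1 `CO[C@@H]1CC=C2N(c3ccc(C)cc3)C(=O)C[C@]2(c2ccccc2)O1` in a functional assay on A549 cells (Homo sapiens) for cytotoxicity, read by sulforhodamine B assay, with a stated time of 48 h (on this read-out higher numbers stand for weaker inhibition and lower numbers for stronger inhibition), gives 3920 nM. Compound 2 `CO[C@@H]1CC=C2N(c3ccc([N+](=O)[O-])cc3)C(=O)C[C@]2(c2ccccc2)O1` gives 7150 nM in this assay. Compound 3 `CO[C@@H]1CC=C2N(c3ccc4[nH]ccc4c3)C(=O)C[C@]2(c2ccccc2)O1` gives 5100 nM in this assay. Compound 3 thus sits between its two neighbours, but all three numbers lie within the scatter of one another: a 1.3-fold higher number from compound 1 to compound 3 (0.11 log units; within the scatter), and a 1.4-fold lower number from compound 2 to compound 3 (0.15 log units; within the scatter).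

Compound 4 `CO[C@@H]1CC=C2N(c3cc(Cl)cc(Cl)c3)C(=O)C[C@]2(c2ccccc2)O1` is not yet measured. It differs from compound 3 by 3,5-dichlorophenyl in place of 1H-indol-5-yl on an amide-type nitrogen in a ring. Every step seen so far is a swap of the aromatic group on that same nitrogen, and none of them moved the number beyond the scatter: a 1.8-fold higher number from compound 1 to compound 2 (0.26 log units; within the scatter), a 1.3-fold higher number from compound 1 to compound 3 (0.11 log units; within the scatter), a 1.4-fold lower number from compound 2 to compound 3 (0.15 log units; within the scatter). A fourth swap at the same place is therefore expected to behave alike, with no step beyond the scatter in this assay, which is expressed as a 1.1-fold lower number from compound 3 to compound 4 (0.03 log units; within the scatter). For compound 4 the estimated value in this assay is 4800 nM, expected to fall between 1900 nM and 12000 nM.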

Compound 4, half-maximal inhibitory concentration: 7530 nM
Estimate against measurement, compound 4: 1.6-fold (0.20 log units) below; measured number inside the range.
By their numbers in this assay, from the lowest: compounds 1, 3, 2 and 4 (each within the scatter of the next).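

Replacing the 1H-indol-5-yl group and its hydrogen-bond donor with 3,5-dichlorophenyl, which puts two chlorine atoms on the ring, still leaves the result in this assay within the scatter of every earlier compound: a 1.5-fold higher number from compound 3 to compound 4 (0.17 log units; within the scatter), a 1.1-fold higher number from compound 2 to compound 4 (0.02 log units; within the scatter) and a 1.9-fold higher number from compound 1 to compound 4 (0.28 log units; within the scatter). Across these four aromatic groups on the amide-type nitrogen, then, no step leaves the scatter, even with a group carrying two chlorine atoms. Nothing measured here offers an explanation for this flat result.

As far as these compounds go, all four groups on this nitrogen are aromatic rings, so it remains open whether a phenyl ring bearing an amine or a carboxylic acid, or a plain butyl chain in place of the ring, would stay within the same range. The phenyl group on the shared core is the same in all four compounds, so nothing shows how the number responds to a change there.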